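Phenyl to 2-Methylpyridin-4-yl: Expected Largest Response

The compounds below may be only part of what the source reports. "The series", "measured", "known", "first", "only" and "open" are said of these compounds alone.

Measured so far:
compound 1 `NS(=O)(=O)c1ccc(-c2nc(C(c3ccc(F)cc3)c3ccc(F)cc3)sc2CC(=O)O)cc1`: 80%
compound 2 `O=C(O)Cc1sc(C(c2ccc(F)cc2)c2ccc(F)cc2)nc1-c1cc(F)nc(F)c1`: 80%
compound 3 `O=C(O)Cc1sc(C(c2ccc(F)cc2)c2ccc(F)cc2)nc1-c1ccccc1`: 80%

All three were tested in an in vitro functional assay on HEK285-7 cells for antagonist activity at prostaglandin D2 receptor 2 (Homo sapiens), read by BRET and beta-arrestin recruitment; a lower number here means a smaller maximal response, a higher number a larger maximal response. Compound 3 stands level with compounds 1 and 2: the step of no change at the digits printed from compound 1 to compound 3 (within the scatter) and the step of no change at the digits printed from compound 2 to compound 3 (within the scatter) both lie within the scatter, and the step of no change at the digits printed from compound 1 to compound 2 (within the scatter) does likewise. Across these three compounds the largest response reached has not moved, whatever group sits on the shared core at that position.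

Compound 4 `Cc1cc(-c2nc(C(c3ccc(F)cc3)c3ccc(F)cc3)sc2CC(=O)O)ccn1` is the next compound, not yet measured. It differs from compound 3 as follows: 2-methylpyridin-4-yl in place of phenyl on an aromatic carbon. Among the measured compounds shown here, the step that bears most directly on this change is the one from compound 2 to compound 3, where a different pyridinyl group was exchanged for phenyl and nothing moved beyond the scatter; the exchange of 4-sulfamoylphenyl for 2,6-difluoropyridin-4-yl between compound 1 and compound 2 was likewise flat. The expected step is therefore no change at the digits printed from compound 3 to compound 4 (within the scatter), a change within the scatter. For compound 4 the largest response reached in this assay is estimated at 80%, with a range from 66% to 94%.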

Compound 4, largest response reached (reported as efficacy), in percent of the reference or control that the assay uses: 80%
The estimate for compound 4 equals the measured number at the digits printed, and the stated range covers the measured number.
By their numbers in this assay, from the lowest: compounds 1, 2, 3 and 4 (each within the scatter of the next).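

In this assay, placing 2-methylpyridin-4-yl on this aromatic carbon of the five-membered aromatic ring adds a ring nitrogen, a methyl group and a hydrogen-bond acceptor to what phenyl offers, yet the result is flat (no change at the digits printed from compound 3 to compound 4 (within the scatter)). The new group also reads flat against the two larger replacements tested here, 2,6-difluoropyridin-4-yl (no change at the digits printed from compound 2 to compound 4 (within the scatter)) and 4-sulfamoylphenyl (no change at the digits printed from compound 1 to compound 4 (within the scatter)), so a methyl-bearing pyridine ring now joins the groups tolerated at this position without any shift in the largest response. No supporting data are available to explain this flatness.

As far as these compounds go, whether an amine or a longer chain on this ring would also leave the largest response unmoved remains open. So does whether a group other than carboxymethyl on the neighbouring ring atom would change the picture.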